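Ester-linked selenocyanate chain lengthened by one carbon

The source may hold more compounds than are shown below. What is called first, only, known or untested is meant among the compounds shown, and "the series" means these compounds.

Going by the values given here, compound 2 `COc1ccc(N(C)c2nc(C)nc3ccccc23)cc1OCCCCC[Se]C#N` stands highest of the three numbers so far in a functional assay on A549 cells (Homo sapiens) for inhibition, read by MTT assay, with a stated time of 48 h; a lower number here means a stronger inhibitor, a higher number a weaker inhibitor: compound 2 gives 2440 nM, whereas compound 1 `COc1ccc(N(C)c2nc(C)nc3ccccc23)cc1C(=O)OCCC[Se]C#N` gives 250 nM and compound 3 `Cc1nc(N(C)c2ccc([Se]C#N)c(F)c2)c2ccccc2n1` gives 4 nM. Compound 3 carries a different pattern of groups on its aryl ring, so its gap to compound 2 is noted only as what the two values show.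

The unmeasured compound 4 `COc1ccc(N(C)c2nc(C)nc3ccccc23)cc1C(=O)OCCCC[Se]C#N` differs from compound 2 in one place, on an aromatic carbon of the six-membered carbon ring, ortho to a methoxy group and meta to a large group: a group of 10 heavy atoms (6 carbon, 1 nitrogen, 2 oxygen, 1 selenium; no ring) in place of a group of 9 heavy atoms (6 carbon, 1 nitrogen, 1 oxygen, 1 selenium; no ring), on an aromatic carbon. The entering group is the ester-linked chain of compound 1 extended by one carbon.

Among the compounds with values here, one measured step bears on this change. Going a 9.8-fold higher number from compound 1 to compound 2 (0.99 log units; beyond the scatter) replaced the ester-linked chain with the ether-linked one, a modest rise. Within the data shown here, compound 4 reverses most of that exchange while keeping a chain one atom longer than in compound 1, so a drop of similar size, toward compound 1, is expected in this assay, though the single supporting step leaves the magnitude uncertain.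

Compound 4 is therefore expected to show a 6.1-fold lower number from compound 2 to compound 4 (0.79 log units; beyond the scatter). Compound 4 is estimated at 400 nM, within a range from 150 nM to 1200 nM.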

Compound 4, half-maximal inhibitory concentration: 155 nM
Estimate against measurement, compound 4: 2.6-fold (0.41 log units) above, and the stated range covers the measured number.
By their numbers in this assay, from the lowest: compound 3; then compounds 4 and 1 (each within the scatter of the next); then compound 2.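

In this assay, placing the ester-linked chain on this aromatic carbon, ortho to a methoxy group, in place of the ether-linked chain gives a 16-fold lower number from compound 2 to compound 4 (1.20 log units; beyond the scatter) and shows that the ester-linked chain retains its advantage when it carries one more carbon, so that the higher number of compound 2 no longer rests on compound 1 alone. Lengthening the saturated chain of the ester gives a 1.6-fold lower number from compound 1 to compound 4 (0.21 log units; within the scatter) and so leaves compound 1 and compound 4 indistinguishable in this assay, which means that this one-carbon extension has no readable effect while the exchange of linked chains carries a large one, although compound 2 is the only ether-linked example and the pattern rests on these three compounds. No measurement available here explains the gap between the ester-linked and ether-linked chains.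

An ether-linked chain matched in length to the chain of compound 4 would separate the link from the chain length, which compound 2 cannot do. As far as these compounds go, a longer chain on the ester and an amide in place of the ester remain open, so the limits of this tolerance at the position are not yet defined.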